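Ring change from compound 3 to compound 4

The compounds below may be only part of what the source reports. "The series", "measured", "known", "first", "only" and "open" are said of these compounds alone.

Measured in a physicochemical assay for solubility, in phosphate buffer, at pH 7.4; on this read-out lower numbers stand for lower solubility and higher numbers for higher solubility:
- compound 1 `CC(=O)N[C@@H]1CCC[C@H](C(=O)Nc2cc(-c3cnc(C)n3C(C)C)ccn2)C1`: 660000 nM
- compound 2 `CC(=O)N[C@@H]1CCC[C@H](C(=O)Nc2cc(-c3cnc4ccccn34)c(Cl)cn2)C1`: 120000 nM
- compound 3 `CC(=O)N[C@@H]1CCC[C@H](C(=O)Nc2cc(-c3cnn4c3CCCCC4)c(Cl)cn2)C1`: 104000 nM

Compound 3 at 104000 nM cannot be told apart from compound 2 at 120000 nM, and both lie well under compound 1 at 660000 nM. Compound 4 `CC(=O)N[C@@H]1CCC[C@H](C(=O)Nc2cc(-c3cnn4c3CC(C)(C)C4)c(Cl)cn2)C1` is still unmeasured. Its change is a group of 10 heavy atoms (8 carbon, 2 nitrogen; one five-membered non-aromatic ring with 1 hetero atom, one five-membered aromatic ring with 2 hetero atoms) in place of a group of 10 heavy atoms (8 carbon, 2 nitrogen; one five-membered aromatic ring with 2 hetero atoms, one seven-membered non-aromatic ring with 1 hetero atom), on an aromatic carbon; the two have the same atoms, joined differently. Among the measured compounds shown here, one measured step bears on this, a 1.2-fold lower number from compound 2 to compound 3 (0.06 log units; within the scatter), a swap of the group at the same place, and it stayed within the scatter. For the measured compounds named here, that single step is thin evidence, and no measured compound carries the entering group. No shift beyond the scatter in this assay is expected. The estimated step is a 1.1-fold higher number from compound 3 to compound 4 (0.02 log units; within the scatter). The expected value for compound 4 is 110000 nM, with an estimated range of 55000 nM to 220000 nM.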

Compound 4, solubility: 150000 nM
Beside the measured number, compound 4's estimate is 1.4-fold (0.13 log units) below it, within the range that was stated.
By their numbers in this assay, from the lowest: compounds 3, 2 and 4 (each within the scatter of the next); then compound 1.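

In this assay, a third group on this aromatic carbon stays within the scatter: a 1.4-fold higher number from compound 3 to compound 4 (0.16 log units; within the scatter), and a 1.3-fold higher number from compound 2 to compound 4 (0.10 log units; within the scatter). Rejoining the same atoms, with a five-membered non-aromatic ring in place of a seven-membered non-aromatic ring, therefore gives no readable change, and a five-membered non-aromatic ring now joins the two earlier groups without separating from them. No available data explain this flat result.

As far as these compounds go, whether an amine or a carboxylic acid on this carbon would move the number beyond the scatter stays open. The compounds shown also do not separate the contribution of the chloro group from that of the group on this carbon, since compound 1 differs from the others in more than one place.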